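This account rests on a few compounds, and the source may have more. Where it says the series, first, only, none or still open, it means among the compounds named here.

Compound 1 `Nc1cc(N)c2nc(-c3ccccc3)c(Oc3ccc(Cl)c(Cl)c3)nc2c1` stands at the lower of the two numbers in a functional assay on SR cells (Homo sapiens) for inhibition, read by sulforhodamine B assay, with a stated time of 48 h (on this read-out lower numbers stand for stronger inhibition of growth and higher numbers for weaker inhibition of growth), where compound 1 gives 24000 nM. Compound 2 `CCOC(=O)[C@H](CCC(=O)O)NC(=O)c1ccc(Sc2nc3cc(N)cc(N)c3nc2-c2ccccc2)cc1` gives 81300 nM in this assay, a higher number that lies beyond the scatter; the two differ in more than one place, so nothing further is drawn from the pair. Compound 3 `Nc1cc(N)c2nc(-c3ccccc3)c(Oc3ccc(F)cc3)nc2c1` carries 4-fluorophenyl in place of 3,4-dichlorophenyl on an oxygen on an aromatic ring. Among the compounds with values here, no measured pair covers this change. A small weakening, close to the scatter, is expected in this assay, so the step of a 1.5-fold higher number from compound 1 to compound 3 (0.16 log units; within the scatter) is estimated. Compound 3 is expected to give 35000 nM, within 12000 nM to 100000 nM.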

Compound 3, concentration for total growth inhibition: < 100000 nM
Compound 3: a limit, no number; the forecaster's own chance of this, stated with the estimate: 20%; the middle value does not contradict the limit.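

In this assay, within the data shown here, compound 3 gives < 100000 nM as a limit and not a number, so no step from compound 1 to compound 3 can be read. Going by these compounds, whether 4-fluorophenyl in place of 3,4-dichlorophenyl strengthens or weakens inhibition of growth stays open.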